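The compounds below may be only part of what the source reports. "The series", "measured", "known", "first", "only" and "open" are said of these compounds alone.

Compound 1 `Cc1cccc2cc3c(nc12)-c1nc2ccccc2n1C3`: in a functional assay on HT-1080 cells (Homo sapiens) for cytotoxicity, read by MTT assay, with a stated time of 72 h (on this read-out higher numbers stand for weaker inhibition and lower numbers for stronger inhibition), compound 1 gives > 100000 nM, which is a limit of the assay and not a number.
Compound 2 `Cc1ccc2cc3c(nc2c1)-c1nc2ccccc2n1C3`: in this assay compound 2 gives 8700 nM.
Compound 3 `COc1cccc2cc3c(nc12)-c1nc2ccccc2n1C3`: in this assay compound 3 gives > 100000 nM, again a limit and not a number.

For the measured compounds named here, compound 2 is thus the only compound with a number; the other two values are limits. Compounds 1 and 2 have the same atoms joined differently, and the difference between the two cores is not broken down here. Compound 3 differs from compound 1 by methoxy in place of methyl on an aromatic carbon. The step that the two limits leave unreadable from compound 1 to compound 3 cannot be read, because the limit of > 100000 nM in this assay, at which 2 of the 3 values shown sit, holds both ends of it.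

Compound 4 `COc1ccc2cc3c(nc2c1)-c1nc2ccccc2n1C3` is not yet measured and differs from compound 2 by methoxy in place of methyl on an aromatic carbon. This is the same kind of change as from compound 1 to compound 3, though the place is not the same: there the group sits ortho to a fused ring and meta to a fused ring, here meta to a fused ring and para to a fused ring. The measured step offers no size to carry over. The expectation therefore rests on compound 2 alone, whose value in this assay is 8700 nM. The step of a 1.1-fold higher number from compound 2 to compound 4 (0.06 log units; within the scatter) is expected to stay within the usual scatter. Compound 4 is estimated at 10000 nM, with a range from 2500 nM to 60000 nM.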

Compound 4, half-maximal inhibitory concentration: 95000 nM
Compound 4: the middle estimate sits 9.5-fold (0.98 log units) below what was measured; measured number outside the range, above it.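

In this assay, for the compounds shown here, methoxy in place of methyl gives an 11-fold higher number from compound 2 to compound 4 (1.04 log units; beyond the scatter), and this is the only size for this change that can be read. The same change from compound 1 to compound 3, on the other core, cannot be read, since both of its values are limits of the assay and not numbers, so nothing shows whether the step carries over from one core to the other: the limit of > 100000 nM in this assay, at which 2 of the 4 values shown sit.

Going by these compounds alone, the single readable step therefore holds for one core and one place only, with the group meta to a fused ring and para to a fused ring, and it sets no rule for the series.

The compounds shown leave open what a bare hydrogen would do at this place, since methyl and methoxy are the only groups that appear there. They also leave open how an amine, a carboxylic acid or a longer chain such as ethoxy would behave on either core.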